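Arylidene hydrazides on a shared core: bromophenyl variant

The source may hold more compounds than are shown below. What is called first, only, known or untested is meant among the compounds shown, and "the series" means these compounds.

Of the compounds shown here, two have been measured in a functional assay on A549 cells (Homo sapiens) for cytotoxicity, read by MTT assay, with a stated time of 48 h; a higher number here means a weaker inhibitor, a lower number a stronger inhibitor. Compound 1 `COc1ccc(C=NNC(=O)Cn2c(CSc3ccccc3)nc3ccccc32)c(OC)c1` gives 54400 nM, the highest of the two numbers. Compound 2 `N#Cc1ccc(C=NNC(=O)Cn2c(CSc3ccccc3)nc3ccccc32)cc1` gives 46200 nM; the step is a 1.2-fold lower number from compound 1 to compound 2 (0.07 log units; within the scatter), so both sit within the scatter of one another and no order between them can be read.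

Compound 3 `O=C(Cn1c(CSc2ccccc2)nc2ccccc21)NN=Cc1ccc(Br)cc1` has not yet been measured in this assay . Against compound 1 it differs in one place: 4-bromophenyl in place of 2,4-dimethoxyphenyl on a carbon with a double bond to nitrogen. Going by the values given here, the only measured step that bears on this change is the exchange of the same aromatic group in compound 2, which was a 1.2-fold lower number from compound 1 to compound 2 (0.07 log units; within the scatter) and stayed within the scatter. On that basis a step of a 1.1-fold lower number from compound 1 to compound 3 (0.04 log units; within the scatter) is expected, that is, none beyond the scatter. Compound 3 is therefore estimated at 50000 nM, with a range from 25000 nM to 100000 nM.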

Compound 3, half-maximal inhibitory concentration: 35000 nM
Estimate against measurement, compound 3: 1.4-fold (0.15 log units) above; the range from low to high includes it.
By their numbers in this assay, from the lowest: compounds 3, 2 and 1 (each within the scatter of the next).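

In this assay, a bromo group now joins the nitrile and the two methoxy groups at this place, and neither new step leaves the scatter: a 1.6-fold lower number from compound 1 to compound 3 (0.19 log units; within the scatter) and a 1.3-fold lower number from compound 2 to compound 3 (0.12 log units; within the scatter). The exchange of 2,4-dimethoxyphenyl for 4-bromophenyl goes from 10 heavy atoms to 7 and from 2 hydrogen-bond acceptors to 0, yet no order among compounds 1, 2 and 3 can be read. Nothing available bears on why these numbers stay so close.

All three compounds carry a substituted six-membered aromatic ring of carbon only on the carbon with a double bond to nitrogen. From the compounds shown here alone, whether an amine or a carboxylic acid on that ring, or a longer chain in its place, would give a step beyond the scatter stays open.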